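Working notes: from compound 3 to compound 4

A few compounds are considered here, and "the series" means these few. Any claim that something is new, unique, unknown or untested is made for them only; others in the source may bear on it.

Measured so far in an assay on CHO cells for displacement of a labelled ligand from adenosine receptor A1 (Homo sapiens), read by scintillation counting, with a stated time of 1 h, tested at 1 uM; a lower number here means less inhibition, a higher number more inhibition at the concentration tested (going by the name of the read-out):
compound 1 `Nc1ncc(-c2ccccc2)c(-c2ccccc2)n1` gives 32%
compound 2 `Nc1ncc(-c2ccccc2)c(-c2ccco2)n1` gives 26%
compound 3 `CCCC(=O)Nc1ncc(-c2cccc(Cl)c2)c(-c2ccccc2)n1` gives > 80%

Going by the values given here, the one measured step between compounds that differ in a single place, furan-2-yl in place of phenyl on an aromatic carbon, gives a number 6 percentage points lower from compound 1 to compound 2 (within the scatter). The value of compound 3 is a limit of this assay and not a number. Compound 3 therefore stands at the limit of > 80% in this assay, at which 1 of the 3 values shown sits. Compounds 1 and 3 differ in two places, so their values show only that the acylated, chlorinated compound 3 reaches the limit while compound 1 does not.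

Compound 4 `OCCCCNc1ncc(-c2cccc(Cl)c2)c(-c2ccccc2)n1` differs from compound 3 in one place: 4-hydroxybutyl in place of propylcarbonyl on a nitrogen on an aromatic ring. Among the compounds with values here, no measured step touches this nitrogen; the only step on record concerns an aromatic carbon and lies within the scatter, so it gives no direction for the change at hand. With compound 3 at the limit, the read-out can only stay at the limit or fall. For compound 4 the expected step in this assay is a number at least 20 percentage points lower from compound 3 to compound 4 (beyond the scatter). Compound 4 is estimated at 60%, with a range from 30% to 85%.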

Compound 4, a percentage reported as inhibition, at one concentration (the size of the read-out at that concentration, not a potency): > 80%
Compound 4 ended at the assay's limit (the forecaster's own chance of this, stated with the estimate: 30%); at least 20 percentage points between middle value and limit.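

Going by these compounds alone, compound 3 and compound 4 both stand at a limit of the assay and not at a number, so no step between them can be read. The compounds shown leave open how far apart the two lie, and whether (4-hydroxybutyl)amino or (propylcarbonyl)amino gives more inhibition at the concentration tested.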